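This account rests on a few compounds, and the source may have more. Where it says the series, first, only, none or still open, it means among the compounds named here.

Measured compounds:
- compound 1, `CC(=O)COc1cc(=O)oc2cc(OCc3cccc(Cl)c3)ccc12`: 26.9 nM in an assay on isolated protein (strain Sprague-Dawley) for inhibition of Amine oxidase [flavin-containing] B (Rattus norvegicus), read by spectrophotometry, with a stated time of 5 min; a higher number here means a weaker inhibitor, a lower number a stronger inhibitor
- compound 2, `NC(=O)COc1cc(=O)oc2cc(OCc3cccc(Cl)c3)ccc12`: 3.1 nM; 3.31 nM (2 entries) in this assay

Compound 1 carries a 2-oxopropoxy group on its core, and in this assay compound 1 gives 26.9 nM. Compound 2 has an amide in place of the ketone of that side chain; in this assay compound 2 gives 3.1 nM; 3.31 nM (2 entries), and the repeated entries, (the several entries of compound 2 in this assay, 3.1 nM; 3.31 nM (2 entries)), lie close together. Of the two numbers shown, compound 1 is the higher one.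

Compound 3, `O=c1cc(Cl)c2ccc(OCc3cccc(Cl)c3)cc2o1`, has not yet been measured in this assay. It differs from compound 1 in one place: chloro in place of 2-oxopropoxy on an aromatic carbon. The whole side chain is gone and a single chlorine stands where it was.

Within the data shown here, no step between measured compounds speaks to this change, since compound 1 and compound 2 differ only within the side chain. The expectation is a modest step from compound 1 to compound 3 towards a weaker inhibitor, of size a 1.5-fold higher number from compound 1 to compound 3 (0.17 log units; within the scatter), and it could well fall within the scatter. Compound 3 is therefore estimated at 40 nM in this assay, with a range from 8 nM to 200 nM.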

Compound 3, half-maximal inhibitory concentration: 20.9 nM
Beside the measured number, compound 3's estimate is 1.9-fold (0.28 log units) above it, and the stated range covers the measured number.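

In this assay the swap of the 2-oxopropoxy group for chloro gives a 1.3-fold lower number from compound 1 to compound 3 (0.11 log units; within the scatter), so this aromatic carbon, opposite the ring oxygen, tolerates a very large cut in the group it carries. The earlier compounds shown here changed only the end of the side chain, whereas this pair shows that the whole chain, with its 5 heavy atoms and 2 hydrogen-bond acceptors, can give way to 1 chlorine atom without the number moving beyond ordinary scatter. Nothing measured here explains why such different groups read alike.

As far as these compounds go, what stays open is how other groups on this aromatic carbon would read, such as an amine, a carboxylic acid, a methyl, a bromine or a longer ether chain, and whether any of them would move the number clearly beyond the scatter. A single pair also cannot tell whether chloro and 2-oxopropoxy would still read alike on a core carrying different groups elsewhere.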